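The source may report more compounds than this note shows. Statements on the series, on what has been measured and on what is new or still open speak of the compounds shown alone.

Of the compounds shown here, three that share one core have been measured in a functional assay on M14 cells (Homo sapiens) for inhibition, read by sulforhodamine B assay, with a stated time of 48 h; a higher number here means a weaker inhibitor of growth, a lower number a stronger inhibitor of growth. Compound 1 `COc1cc(-c2nn(-c3cccc(NC(=O)c4cccc(C(F)(F)F)c4)c3)cc2-c2ccncc2)ccc1Cl` sits at the assay's limit (the limit of > 50000 nM in this assay, at which 1 of the 3 values shown sits), giving > 50000 nM. Among the measured compounds shown here, compound 3 `COc1cc(-c2nn(-c3cccc(NC(=O)c4ccccc4)c3)cc2-c2ccncc2)ccc1Cl` gives 12900 nM, and the single measured step, an at least 3.8-fold lower number from compound 1 to compound 3 (0.58 log units; beyond the scatter), is exactly this kind of change: hydrogen in place of trifluoromethyl on an aromatic carbon. Compound 2 `O=C(Nc1cccc(-n2cc(-c3ccncc3)c(-c3ccc(Cl)c(O)c3)n2)c1)Nc1cc(C(F)(F)F)cc(C(F)(F)F)c1` gives 1810 nM, the lowest of the two actual numbers shown. Compound 4 `O=C(Nc1cccc(-n2cc(-c3ccncc3)c(-c3ccc(Cl)c(O)c3)n2)c1)Nc1cccc(C(F)(F)F)c1` differs from compound 2 by hydrogen in place of trifluoromethyl on an aromatic carbon. Since the same change lowered the number from compound 1 to compound 3, a lower or similar number is expected here, and the step is estimated as a 1.5-fold lower number from compound 2 to compound 4 (0.18 log units; within the scatter). Compound 4 is therefore expected to give 1200 nM, within a range from 400 nM to 3600 nM.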

Compound 4, concentration for total growth inhibition: 10800 nM
Estimate against measurement, compound 4: 9.0-fold (0.95 log units) below, outside the stated range (above it).
By their numbers in this assay, from the lowest: compound 2; then compounds 4 and 3 (each within the scatter of the next). At a limit, above all of these: compound 1.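

Hydrogen in place of trifluoromethyl on this aromatic carbon gives a 6.0-fold higher number from compound 2 to compound 4 (0.78 log units; beyond the scatter), so on this core the change weakens growth inhibition. The same change therefore does not act in one direction on both cores: the same change on two cores in this assay, an at least 3.8-fold lower number (0.58 log units; beyond the scatter) from compound 1 to compound 3 and a 6.0-fold higher number (0.78 log units; beyond the scatter) from compound 2 to compound 4, at least 23-fold (1.36 log units) apart, beyond the scatter of two such steps Compound 1 stands at a limit, not at a true number: the limit of > 50000 nM in this assay, at which 1 of the 4 values shown sits.

From the compounds shown here alone, what a methyl group or an amine would do on this aromatic carbon remains open. Also open, going by these compounds, is which difference between the two cores decides the direction of the step.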